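This account rests on a few compounds, and the source may have more. Where it says the series, first, only, none or still open, it means among the compounds named here.

Measured compounds:
compound 1 `O=C(Nc1nc2ccc(Oc3ccc(F)c(NCc4cccc(C(F)(F)F)c4)c3)cc2s1)C1CC1`: "not determined" (no result reported)
compound 2 `CCOC(=O)c1cccc(NC(=O)Nc2cc(Oc3ccc4nc(NC(=O)C5CC5)sc4c3)ccc2F)c1`: > 50000 nM
compound 3 `O=C(Nc1nc2ccc(Oc3ccc(F)c(NS(=O)(=O)c4cccc(C(F)(F)F)c4)c3)cc2s1)C1CC1`: "not determined" (no result reported)

Of the compounds shown here, three built on a shared core have been tested in an ADME assay on HT-29 cells (Homo sapiens) for cytotoxicity, read by luminescence and CellTiter-Glo, with a stated time of 12 h; a lower number here means that less compound is tolerated, a higher number that more compound is tolerated. For compound 1 the entry in this assay is "not determined" (no result reported), and for compound 3 the entry is likewise "not determined" (no result reported), so neither contributes a usable number. Compound 2 is the only one of the three with a reported result, and that result is a limit of the assay rather than a number: in this assay compound 2 gives > 50000 nM. This sits at the limit of > 50000 nM in this assay, at which 1 of the 3 values shown sits. Within the data shown here, no pair of compounds here differs in just one place with two numbers on both sides, so no measured step shows how a change on this part of the molecule moves the read-out.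

Compound 4, `COc1cccc(NC(=O)Nc2cc(Oc3ccc4nc(NC(=O)C5CC5)sc4c3)ccc2F)c1`, is the compound yet to be measured. It differs from compound 2 in one place: methoxy in place of ethoxycarbonyl on an aromatic carbon. With compound 2 resting at a limit, the change from compound 2 to compound 4 is expected to yield a step of a number no higher from compound 2 to compound 4 (the limit leaves the size open), that is, nothing beyond the usual scatter. Compound 4 is therefore estimated to give about 50000 nM in this assay, with a range from 20000 nM to 100000 nM, and it is quite likely that only a limit will again be reported.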

Compound 4, half-maximal cytotoxic concentration: > 50000 nM
Compound 4: a limit, no number (the forecaster's own chance of this, stated with the estimate: 70%); the middle value sits exactly at the limit.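

In this assay compound 2 and compound 4 both rest at a limit and not at a number, so no step can be read for methoxy in place of ethoxycarbonyl: the limit of > 50000 nM in this assay, at which 2 of the 4 values shown sit. The compounds shown leave open at what concentration, if any, compound 2 or compound 4 would reach the half-maximal cytotoxic effect, and how the two truly compare.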